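This account rests on a few compounds, and the source may have more. Where it says the series, first, only, none or still open, it means among the compounds named here.

Measured in a physicochemical assay for lipophilicity, using the shake flask method, in phosphate buffer, measured as octanol-water partition, with a stated time of 30 min, at pH 7.4; a lower number here means a more polar compound, a higher number a more lipophilic compound:
- compound 1 `Fc1ccc2c(c1CNc1ncc(Oc3ccccc3)c3nncn13)CCO2`: 3.5
- compound 2 `CN(c1ccccc1)c1cnc(NCc2c(F)ccc3c2CCO3)n2cnnc12`: 3.6
- compound 3 `C[C@H]1CC(=O)N(c2cnc(NCc3c(F)ccc4c3CCO4)n3cnnc23)C1`: 1.8

Among these three, compound 3 stands lowest at 1.8. Reaching it took large steps from both other compounds: a number 1.70 log units lower from compound 1 to compound 3 (beyond the scatter), and a number 1.80 log units lower from compound 2 to compound 3 (beyond the scatter). Exchanging the groups of the first two made little difference, with a number 0.10 log units higher from compound 1 to compound 2 (within the scatter).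

The next structure is compound 4 `CN(c1cccnc1)c1cnc(NCc2c(F)ccc3c2CCO3)n2cnnc12`, which has methyl(pyridin-3-yl)amino in place of 4-methyl-2-oxopyrrolidin-1-yl on an aromatic carbon. The closest guide is compound 2, which carries methyl(phenyl)amino, and its measured a number 1.80 log units lower from compound 2 to compound 3 (beyond the scatter), read backward, points to a rise in this assay. Within the data shown here, no measured step covers a pyridin-3-yl ring, so only part of that size is expected, though still beyond the scatter. The expected step is a number 0.80 log units higher from compound 3 to compound 4 (beyond the scatter). Compound 4 is estimated at 2.6, within an expected range from 2.1 to 3.1.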

Compound 4, distribution coefficient: 2.6
Compound 4: the middle estimate sits on the measured number at the digits printed; measured number inside the range.
By their numbers in this assay, from the lowest: compound 3; then compound 4; then compounds 1 and 2 (each within the scatter of the next).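

In this assay the aromatic ring on the nitrogen proves to matter at this position: pyridin-3-yl in place of phenyl gives a number 1.00 log units lower from compound 2 to compound 4 (beyond the scatter) while the earlier exchange of phenoxy for methyl(phenyl)amino had stayed within the scatter. Compound 4 therefore takes a middle place, with a number 0.80 log units higher from compound 3 to compound 4 (beyond the scatter) and with a number 0.90 log units lower from compound 1 to compound 4 (beyond the scatter) on the other side, so carrying an aromatic ring on this carbon does not by itself put a compound at the top of this series. Among these compounds, nothing at hand explains why this single ring atom shifts the number so far. The compounds shown leave open whether the place of the ring nitrogen counts, as a pyridin-2-yl or pyridin-4-yl group would tell, and whether a pyrimidin-5-yl ring would go further. On these data alone, what a morpholine or a dimethylamino group would give on the same aromatic carbon also stays open.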